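Hydroxy to methylamino on the shared core

The source may hold more compounds than are shown below. What is called first, only, known or untested is meant among the compounds shown, and "the series" means these compounds.

Working notes on the series. Compound 1 `Nc1nc(O)c2ncn(C3CC(CO)C(O)C3O)c2n1` gives in a functional assay on cells (Cancer cell lines, Homo sapiens) for cytotoxicity (a lower number here means that less compound is needed, a higher number that more compound is needed for the effect), only a limit of the assay, > 100 ug/mL. Compound 2 `Nc1nc(O)c2nnn(C3CC(CO)C(O)C3O)c2n1` likewise gives only a limit in this assay, > 100 ug/mL. Compound 3 `Nc1nc(S)c2ncn(C3CC(CO)C(O)C3O)c2n1` gives 50 ug/mL in this assay. Compound 1 thus stands at the limit of > 100 ug/mL in this assay, at which 2 of the 3 values shown sit, with no number of its own. Compound 4 `CNc1nc(N)nc2c1ncn2C1CC(CO)C(O)C1O` differs from compound 1 as follows: methylamino in place of hydroxy on an aromatic carbon. For the measured compounds named here, the one measured step at this carbon is an at least 2.0-fold lower number from compound 1 to compound 3 (0.30 log units; that floor lies within the scatter), with a different entering group, so no step of the same kind is at hand. Only a small step, if any, is expected, an at least 1.4-fold lower number from compound 1 to compound 4 (0.15 log units; that floor lies within the scatter). For compound 4 the value expected in this assay is 70 ug/mL, between 25 ug/mL and 200 ug/mL.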

Compound 4, concentration for half-maximal effect: 18 ug/mL
Beside the measured number, compound 4's estimate is 3.9-fold (0.59 log units) above it, and the stated range ends above it.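

For the compounds shown here, at this aromatic carbon, methylamino in place of hydroxy gives the first step beyond the scatter in this assay, with an at least 5.5-fold lower number from compound 1 to compound 4 (0.74 log units; beyond the scatter) on the shared core. The entering group also counts at this carbon, since methylamino in place of sulfanyl gives a 2.8-fold lower number from compound 3 to compound 4 (0.44 log units; beyond the scatter) as well. The first step is only a floor, as compound 1 has a limit and no number of its own: the limit of > 100 ug/mL in this assay, at which 2 of the 4 values shown sit.

As far as these compounds go, whether a longer chain on this nitrogen, such as ethylamino, or a dimethylamino group moves the number further remains open. So does whether methylamino has the same effect on the core of compound 2.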